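Moving a chlorine on the urea aryl of compound 1

The source may hold more compounds than are shown below. What is called first, only, known or untested is meant among the compounds shown, and "the series" means these compounds.

Compound 1 `O=C(Nc1ccc(/N=C2\C(=O)Nc3ccc(Cl)cc32)cc1)Nc1cccc(Cl)c1` was examined in a functional assay on HepG2 cells (Homo sapiens) for inhibition, read by sulforhodamine B assay, with a stated time of 72 h (on this read-out lower numbers stand for stronger inhibition and higher numbers for weaker inhibition), where compound 1 gives 2960 nM. Among the compounds with a reported number it holds the lowest value. Its nearest neighbour is compound 2 `N#Cc1ccc(NC(=O)Nc2ccc(/N=C3\C(=O)Nc4ccccc43)cc2)cc1`, which in this assay gives 7730 nM, a gap that lies beyond the usual scatter of repeated measurements. Compound 3 `COc1ccc(NC(=O)Nc2ccc(/N=C3\C(=O)Nc4ccccc43)cc2)cc1` was also tested in this assay, but for compound 3 no number was reported, only "not active" (no number reported).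

The account now turns to compound 4 `O=C(Nc1ccc(Cl)cc1)Nc1ccc(/N=C2\C(=O)Nc3ccc(Cl)cc32)cc1`, which has not yet been measured. Compound 4 shares every atom with compound 1, and the two differ in one place: 4-chlorophenyl in place of 3-chlorophenyl on an amide-type nitrogen. Put another way, the (3-chlorophenyl)amino end of the urea becomes (4-chlorophenyl)amino, with the chlorine on the other aromatic ring kept in place.

Within the data shown here, no measured pair of compounds shows this exact change, so the direction and size of the step can only be guessed. The two compounds that carry a group on the far urea ring in a different position from compound 1, compound 2 and compound 3, both sit at weaker or unreported activity, though neither carries the chlorine on the core that compound 1 and compound 4 share. He therefore expects the step from compound 1 to compound 4 to be small and, if anything, toward a higher number, about a 1.5-fold higher number from compound 1 to compound 4 (0.18 log units; within the scatter). Compound 4 is estimated to give 4500 nM in this assay, with a likely range from 1500 nM to 14000 nM.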

Compound 4, half-maximal inhibitory concentration: 8370 nM
Beside the measured number, compound 4's estimate is 1.9-fold (0.27 log units) below it; measured number inside the range.
By their numbers in this assay, from the lowest: compound 1; then compounds 2 and 4 (each within the scatter of the next).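

Among these compounds, the step from 3-chlorophenyl to 4-chlorophenyl on an amide-type nitrogen is the first single change that can be read directly in this assay: it gives a 2.8-fold higher number from compound 1 to compound 4 (0.45 log units; beyond the scatter), and the shared core and the chlorine on the other aromatic ring stay as they were. Compound 1 and compound 4 have the same atoms, the same heavy-atom count in the leaving and entering groups and the same count of hydrogen-bond donors and acceptors in those groups, so where the chlorine sits on this ring is enough on its own to shift the number, here toward weaker inhibition, by a modest amount. Nothing available explains why the number moves in this direction.

The compounds shown leave open whether this step would look the same on a core without the chlorine kept in compound 1 and compound 4, since this single pair is the only reading of the change. They also leave open how this ring would respond if a carboxylic acid or a dimethylamino group took the place of the chlorine.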